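Methyl for trifluoromethyl on two aryl ends of one series

The source may report more compounds than this note shows. Statements on the series, on what has been measured and on what is new or still open speak of the compounds shown alone.

Compound 1 `NC(=O)c1c(NC(=O)c2ccccc2C(F)(F)F)sc2c1CCN(C(=S)Nc1ccccc1Cl)C2` and compound 2 `Cc1ccccc1C(=O)Nc1sc2c(c1C(N)=O)CCN(C(=S)Nc1ccccc1Cl)C2` share a core; compound 3 `NC(=O)c1c(NC(=O)c2ccccc2Br)sc2c1CCN(C(=S)Nc1ccccc1C(F)(F)F)C2` carries a core whose difference from the core of compound 1 is not broken down here. In a functional assay on HL-60 cells (Homo sapiens) for antiproliferative activity, with a stated time of 24 h (on this read-out higher numbers stand for weaker inhibition and lower numbers for stronger inhibition), compound 1 gives 17600 nM, compound 2 gives 20900 nM and compound 3 gives 27400 nM. The change methyl in place of trifluoromethyl on an aromatic carbon made the step of a 1.2-fold higher number from compound 1 to compound 2 (0.07 log units; within the scatter). Compound 4 `Cc1ccccc1NC(=S)N1CCc2c(sc(NC(=O)c3ccccc3Br)c2C(N)=O)C1` is unmeasured and differs from compound 3 by methyl in place of trifluoromethyl on an aromatic carbon, the same change, since its place reads word for word as before, though cut one bond further out it also reads (2-(trifluoromethyl)phenyl)amino to (2-methylphenyl)amino. Going by the values given here, the only ground for an expectation is the single earlier step, which stayed within the scatter. Compound 4 is therefore expected near 30000 nM, between 15000 nM and 60000 nM, an estimated step of a 1.1-fold higher number from compound 3 to compound 4 (0.04 log units; within the scatter).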

Compound 4, half-maximal inhibitory concentration: > 50000 nM
Compound 4 was reported as a limit (the forecaster's own chance of this, stated with the estimate: 15%); middle value at least 1.6-fold (0.22 log units) away from the limit.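

In this assay compound 4 gives > 50000 nM, which is a limit of the assay and not a number. On the core of compound 3, methyl in place of trifluoromethyl gives an at least 1.8-fold higher number from compound 3 to compound 4 (0.26 log units; that floor lies within the scatter), so no shift beyond the scatter is established for this core. Carrying the change from one core to another is therefore neither shown to keep its size nor shown to alter it: the same change on two cores in this assay, a 1.2-fold higher number (0.07 log units; within the scatter) from compound 1 to compound 2 and an at least 1.8-fold higher number (0.26 log units; that floor lies within the scatter) from compound 3 to compound 4; the limit leaves it open whether they differ

Open, going by these compounds, is how the change reads on a core where both partners give numbers clear of the limit. Also open, on these data alone, is whether methoxy or ethyl on that aromatic carbon would read differently from methyl or trifluoromethyl.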